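Carboxymethyl in place of isopropyl at compound 3

This account rests on a few compounds, and the source may have more. Where it says the series, first, only, none or still open, it means among the compounds named here.

In a functional assay (mast cells) for inhibition, with Rattus norvegicus as the target (on this read-out higher numbers stand for an effect only at larger amounts of compound and lower numbers for an effect already at smaller amounts), compound 1 (`CC1CC/C(=N\Nc2ccc(O)cc2)c2ncc(C(=O)O)c(=O)n21`) gives 1300 nM and compound 2 (`CC(C)c1ccc(N/N=C2\CCC(C)n3c2ncc(C(=O)O)c3=O)cc1`) gives 1200 nM within the scatter of each other. Compound 3 (`CC1CC/C(=N\Nc2ccc(CC(=O)O)cc2)c2ncc(C(=O)O)c(=O)n21`) is not yet measured and carries carboxymethyl in place of isopropyl on an aromatic carbon para to a large group. Going by the values given here, the only measured step at that carbon (a 1.1-fold lower number from compound 1 to compound 2 (0.03 log units; within the scatter)) puts isopropyl in place of hydroxy and stays within the scatter. Among the compounds with values here, no measured compound carries carboxymethyl, so this single step is thin support. The expected step in this assay is none beyond the scatter (a 1.1-fold higher number from compound 2 to compound 3 (0.03 log units; within the scatter)). For compound 3 the estimated value is 1300 nM with an expected range from 500 nM to 3300 nM as the working figure.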

Compound 3, half-maximal effective concentration: 3400 nM
Estimate against measurement, compound 3: 2.6-fold (0.42 log units) below, and the stated range ends below it.
By their numbers in this assay, from the lowest: compounds 2 and 1 (each within the scatter of the next); then compound 3.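

Going by these compounds alone, at the aromatic carbon para to a large group, the earlier compounds suggested indifference, but in this assay carboxymethyl changes the picture: a 2.8-fold higher number from compound 2 to compound 3 (0.45 log units; beyond the scatter) and a 2.6-fold higher number from compound 1 to compound 3 (0.42 log units; beyond the scatter) are both modest steps beyond the scatter. Of the three groups at this carbon, only carboxymethyl separates from the others, towards a higher number, while hydroxy and isopropyl remain within the scatter of each other. Nothing at hand bears on the reason for this step.

Open, going by these compounds, is whether an amine at this carbon would stay with hydroxy and isopropyl or move with carboxymethyl. Also open, on these data alone, is how a longer chain ending in a carboxylic acid would compare with carboxymethyl.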